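The source may hold more compounds than are shown below. What is called first, only, known or untested is meant among the compounds shown, and "the series" means these compounds.

Compound 1, `COc1cc(-c2ccnc3cc(-c4ccc(C)cc4)nn23)cc(OC)c1OC`: 48 nM
Compound 2, `Cc1ccc(-c2cc3nccc(-c4ccc(F)cc4)n3n2)cc1`: > 10000 nM

Both were tested in a functional assay on HCT-116 cells (Homo sapiens) for inhibition, read by CCK-8 assay, with a stated time of 48 h; on this read-out lower numbers stand for stronger inhibition and higher numbers for weaker inhibition. Among the measured compounds shown here, compound 1 gives 48 nM, the only actual number among the two results. For compound 2 the result is a limit of this assay rather than a number: > 10000 nM. That limit, (the limit of > 10000 nM in this assay, at which 1 of the 2 values shown sits), means the two values cannot be compared as a step.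

Compound 3, `CCOC(=O)c1ccc(-c2cc3nccc(-c4cc(OC)c(OC)c(OC)c4)n3n2)cc1`, is the compound still to be measured. It differs from compound 1 by ethoxycarbonyl in place of methyl on an aromatic carbon; the change sits on an aromatic carbon of a six-membered aromatic ring of carbon only, para to a large group. For the measured compounds named here, no measured pair shows such a change, so there is nothing to lean on beyond the structure itself. The expected outcome is a step of a 2.3-fold higher number from compound 1 to compound 3 (0.36 log units; beyond the scatter) that stays small, at most a little beyond the scatter toward weaker inhibition. Compound 3 is therefore estimated at 110 nM, with a range from 25 nM to 600 nM.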

Compound 3, half-maximal inhibitory concentration: > 10000 nM
Compound 3: a limit, no number; the forecaster's own chance of this, stated with the estimate: 10%; middle value at least 90-fold (1.95 log units) from the limit.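

In this assay, compound 3 gives > 10000 nM, which is a limit of the assay and not a number. Among the compounds shown here, the position on the aromatic carbon, para to a large group, is therefore far from indifferent: ethoxycarbonyl in place of methyl gives an at least 200-fold higher number from compound 1 to compound 3 (2.31 log units; beyond the scatter), a large loss of inhibition that no earlier pair could reveal. The step gives only a minimum size for this loss, because compound 3 stops at a limit, as compound 2 does: the limit of > 10000 nM in this assay, at which 2 of the 3 values shown sit.

As far as these compounds go, with only methyl and ethoxycarbonyl seen at this carbon, it stays open which feature of the ester group matters, or how much change the position accepts. An ethyl group, a carboxylic acid or a primary amide at the same carbon would help to separate these possibilities.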